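The source may hold more compounds than are shown below. What is called first, only, known or untested is meant among the compounds shown, and "the series" means these compounds.

Of the compounds shown here, three have been measured in a functional assay on L1210 cells (Mus musculus), read by cell counting, with a stated time of 48 h; a higher number here means a weaker inhibitor, a lower number a stronger inhibitor. Compound 1 `Clc1ccccc1/C=N/c1ccc(Br)cc1` gives 2.1 ug/mL, and compound 3 `Fc1ccc(/N=C/c2ccccc2Cl)cc1`, which shares its core, gives 6 ug/mL. The change of fluoro in place of bromo on an aromatic carbon brought a 2.9-fold higher number from compound 1 to compound 3 (0.46 log units; beyond the scatter). Compound 2 `Cc1ccc(/C=C/c2ccccc2F)cc1`, built on a different core, gives the highest of the three numbers in this assay, 72 ug/mL, which lies beyond the scatter above both of the others. Compound 4 `Fc1ccc(/C=C/c2ccccc2F)cc1` differs from compound 2 in one place: fluoro in place of methyl on an aromatic carbon. Among the compounds with values here, no measured step involves fluoro in place of methyl, and the only step that has been measured, from compound 1 to compound 3, concerns a different change on a different core and was modest in size. With nothing in the measured compounds pointing to a large effect, the expected step of a 1.0-fold lower number from compound 2 to compound 4 (0.01 log units; within the scatter) is none beyond the scatter. Compound 4 is therefore estimated at 70 ug/mL in this assay, with a range from 25 ug/mL to 200 ug/mL. Within the data shown here, the range is wide, as this change rests on no measured step.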

Compound 4, half-maximal inhibitory concentration: 62 ug/mL
Compound 4: middle estimate off by 1.1-fold (0.05 log units), on the high side; low and high end bracket the measured number.
By their numbers in this assay, from the lowest: compound 1; then compound 3; then compounds 4 and 2 (each within the scatter of the next).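

In this assay, fluoro in place of methyl on an aromatic carbon, para to a group of 9 heavy atoms, brings a 1.2-fold lower number from compound 2 to compound 4 (0.06 log units; within the scatter), so the two groups cannot be told apart at this position. This is the first step shown on this core, and unlike a 2.9-fold higher number from compound 1 to compound 3 (0.46 log units; beyond the scatter), a different change on a different core, it stays within the scatter. Nothing measured here bears on why the two groups read alike.

The compounds shown leave open whether another group at this position, such as an amine, a carboxylic acid or a longer chain, would move the number beyond the scatter. They also leave open whether fluoro in place of methyl would read the same way on the core of compound 1.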